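The source may report more compounds than this note shows. Statements on the series, on what has been measured and on what is new or still open speak of the compounds shown alone.

Measured in a functional assay on PC-12 cells (Rattus norvegicus) for cytotoxicity, read by MTT assay, with stated times of 3 h and 2 h, tested at 50 uM; a higher number here means a stronger effect of the compound at the concentration tested, a lower number a weaker effect:
compound 1 `COc1ccc(-c2cc3ccc(OCCCn4cc(CNC(=O)CCCCC5CCSS5)nn4)cc3oc2=O)cc1` gives 65.7%
compound 2 `O=C(CCCCC1CCSS1)NCc1cn(CCCOc2ccc3cc(-c4ccc(Br)cc4)c(=O)oc3c2)nn1` gives 74.7%
compound 3 `COc1ccc(-c2cc3ccc(OCCCCn4cc(CNC(=O)CCCCC5CCSS5)nn4)cc3oc2=O)cc1` gives 55.3%

Compound 4 `O=C(CCCCC1CCSS1)NCc1cn(CCCCOc2ccc3cc(-c4ccc(Br)cc4)c(=O)oc3c2)nn1` awaits measurement in this assay. The difference between the core of compound 3 and the core of compound 1 is not broken down here. Between compound 1 and compound 2 the change is bromo in place of methoxy on an aromatic carbon, and it gave a number 9 percentage points higher from compound 1 to compound 2 (within the scatter). The same change, at the same place, is made from compound 3 to compound 4: bromo in place of methoxy on an aromatic carbon. Going by the values given here, only this one earlier instance is available, so the expectation rests on that pair alone. Expected is a number 8.7 percentage points higher from compound 3 to compound 4 (within the scatter), because a number 9 percentage points higher from compound 1 to compound 2 (within the scatter). Compound 4 is thus estimated at 64%, with a range from 50% to 78%.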

Compound 4, a percentage reported as activity, at one concentration (the size of the read-out at that concentration, not a potency): 47.6%
Estimate against measurement, compound 4: 16.4 percentage points above; measured number outside the range, below it.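

In this assay, replacing methoxy with bromo, read as 4-methoxyphenyl to 4-bromophenyl, gives a number 7.7 percentage points lower from compound 3 to compound 4 (within the scatter). Set beside the earlier step, this change does not carry over as a fixed increment from one core to the other: the same change on two cores in this assay, a number 9 percentage points higher (within the scatter) from compound 1 to compound 2 and a number 7.7 percentage points lower (within the scatter) from compound 3 to compound 4, 16.7 percentage points apart, beyond the scatter of two such steps This shows that, within these four compounds, the size and direction of the step cannot be assumed to hold across the two cores, but with a single pair per core and each step within the scatter on its own, it shows neither a reliable effect of the change on either core nor a reason for the gap.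

Open, on these data alone, is how an amine or a carboxylic acid would read at that same aromatic carbon on each core. Also open, as far as these compounds go, is whether a longer chain on either core would widen or close the gap between the two steps.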